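The source may report more compounds than this note shows. Statements on the series, on what has been measured and on what is new or still open speak of the compounds shown alone.

Three related compounds have been measured in a functional assay on DU-145 cells (Homo sapiens) for inhibition, read by MTT assay, with stated times of 18 h and 4 h; a lower number here means a stronger inhibitor, a higher number a weaker inhibitor. Compound 2 `CCCCCCCCOP(=O)(O)OCCSC(=S)N1CCCC1` gives 47100 nM. Compound 3 `CCCCCCOP(=O)(O)OCCSC(=S)N1CCCC1` is known only as a limit, > 100000 nM, and has no number of its own.

Compound 4 `CCCCCCCCCCCCCCCCOP(=O)(O)OCCSC(=S)N1CCCC1` departs from compound 3 by a single change: decyl in place of hydrogen on a saturated chain carbon, six bonds along the chain from an oxygen on an unsaturated carbon. The measured step that bears most directly on this change is an at least 2.1-fold higher number from compound 2 to compound 3 (0.32 log units; beyond the scatter). There, ethyl gives way to hydrogen at the same place on the chain, and the number rises beyond the scatter. The true size of that step is not known, as one end of it is a limit.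

The change to compound 4 runs the opposite way and adds a much larger group, so a move towards a lower number is expected, probably greater than the step just described. Compound 1 `CCCCCCCCCCCCCCCCOP(=O)(O)OCCSC(=S)N1CCCCCC1` offers a second guide, as it carries the same long chain as compound 4 on a different ring. Compound 1 gives 17600 nM. Among the compounds with values here, that value is lower than the one for compound 2, which fits the expected direction.

The expected step is an at least 6.6-fold lower number from compound 3 to compound 4 (0.82 log units; beyond the scatter), towards a stronger inhibitor. For compound 4 the estimated value is 15000 nM, with an expected range from 5000 nM to 40000 nM.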

Compound 4, half-maximal inhibitory concentration: 28900 nM
Estimate against measurement, compound 4: 1.9-fold (0.28 log units) below; measured number inside the range.
By their numbers in this assay, from the lowest: compounds 1, 4 and 2 (each within the scatter of the next, the first and the last beyond it). At a limit, above all of these: compound 3.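

In this assay, decyl in place of hydrogen on a saturated chain carbon, six bonds along the chain from an oxygen on an unsaturated carbon, gives an at least 3.4-fold lower number from compound 3 to compound 4 (0.53 log units; beyond the scatter), so this position tolerates a much larger group than the ethyl of the earlier step and the change still moves the number clearly away from the limit. The further lengthening shows no matching gain: octyl in place of hydrogen on a saturated chain carbon, eight bonds along the chain from an oxygen on an unsaturated carbon, gives a 1.6-fold lower number from compound 2 to compound 4 (0.21 log units; within the scatter), a step that cannot be told from the scatter. With this long chain in place, pyrrolidin-1-yl in place of azepan-1-yl on a thiocarbonyl carbon gives a 1.6-fold higher number from compound 1 to compound 4 (0.22 log units; within the scatter), so these two rings cannot be told apart here either.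

Going by these compounds, the full size of the step from compound 3 stays unknown, because compound 3 is known only as a limit: the limit of > 100000 nM in this assay, at which 1 of the 4 values shown sits. Whether a longer chain than that of compound 4, or an amine or a carboxylic acid on the chain, would move the number beyond the scatter remains open.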